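Compound 4: a Bromine Added to the Core of Compound 1

The source may report more compounds than this note shows. Statements on the series, on what has been measured and on what is new or still open speak of the compounds shown alone.

Measured in a functional assay on MCF7 cells (Homo sapiens) for antiproliferative activity, read by MTT assay, with a stated time of 48 h; on this read-out higher numbers stand for weaker inhibition and lower numbers for stronger inhibition:
compound 1 `N=C(N)N/N=C(/C=C/c1ccccc1)c1ccccc1` — 17000 nM
compound 2 `N=C(N)N/N=C(/C=C/c1ccc(-c2ccccc2)cc1)c1ccccc1` — 800 nM
compound 3 `COc1ccc(/C=C/C(=N/NC(=N)N)c2ccccc2)cc1` — 14000 nM

Compound 1 gives the highest of the three numbers. Compound 3 stands nearest to it, the step of a 1.2-fold lower number from compound 1 to compound 3 (0.08 log units; within the scatter) lying within the scatter, while compound 2 stands furthest away, with a 21-fold lower number from compound 1 to compound 2 (1.33 log units; beyond the scatter). Compound 4 `N=C(N)N/N=C(/C=C/c1ccccc1Br)c1ccccc1` differs from compound 1 by bromo in place of hydrogen on an aromatic carbon. Neither measured step bears on this change directly: the large step to compound 2 and the flat step to compound 3 both concern other groups, and neither puts anything at the place the bromo takes, ortho to a large group. Only compound 2 shows that the shared core can reach a far lower number, and that required phenyl. Without a closer precedent, no step beyond the scatter is expected in this assay, and the step expected from compound 1 to compound 4 is a 1.4-fold lower number from compound 1 to compound 4 (0.15 log units; within the scatter). Compound 4 is therefore estimated at 12000 nM, within a range from 4000 nM to 40000 nM.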

Compound 4, half-maximal inhibitory concentration: 4200 nM
Compound 4: middle estimate off by 2.9-fold (0.46 log units), on the high side, within the range that was stated.
By their numbers in this assay, from the lowest: compound 2; then compound 4; then compounds 3 and 1 (each within the scatter of the next).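

Placing bromo on an aromatic carbon, ortho to a large group, gives a 4.0-fold lower number from compound 1 to compound 4 (0.61 log units; beyond the scatter) in this assay and so shows that the shared core responds to a single heavy atom at this place. The earlier steps shown here, which concern another place, did not show this: methoxy gave a 1.2-fold lower number from compound 1 to compound 3 (0.08 log units; within the scatter) and only phenyl moved the number beyond the scatter, with a 21-fold lower number from compound 1 to compound 2 (1.33 log units; beyond the scatter) still the large step. No measurement shown here accounts for the effect of bromo at this position.

Going by these compounds, whether this step belongs to bromo itself or would follow from other groups at the same place remains open, and chloro, methyl or an amine there would test that. On these data alone, it is also open whether bromo elsewhere on this ring would give a similar step.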